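A few compounds are considered here, and "the series" means these few. Any claim that something is new, unique, unknown or untested is made for them only; others in the source may bear on it.

Three compounds have been measured in a functional assay on CHO cells for agonist activity at Free fatty acid receptor 2 (Homo sapiens), read by cAMP accumulation; on this read-out higher numbers stand for weaker inhibition and lower numbers for stronger inhibition:

compound 1, `CC(C)C(c1ccc(Cl)cc1)S(=O)(=O)Nc1nccs1`: > 100000 nM
compound 2, `CC(C)[C@H](C(=O)NCc1ccccc1)c1ccc(Cl)cc1`: > 100000 nM
compound 3, `CC(C)[C@H](C(=O)Nc1ccon1)c1ccc(Cl)cc1`: 36000 nM

Compound 2 gives only a limit of the assay, > 100000 nM, so its true value is not known. Compound 1 also gives only a limit, > 100000 nM. Two of the three values therefore sit at the limit of > 100000 nM in this assay, at which 2 of the 3 values shown sit; compound 3 is the one that reached a measurable number.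

Compound 4, `CC(C)[C@H](C(=O)NC1=NC(=O)CS1)c1ccc(Cl)cc1`, has not been measured. It differs from compound 2 in one place: a group of 6 heavy atoms (3 carbon, 1 nitrogen, 1 oxygen, 1 sulfur; one five-membered non-aromatic ring with 2 hetero atoms) in place of a group of 7 heavy atoms (7 carbon; one six-membered aromatic ring of carbon only), on an amide-type nitrogen. Among the measured compounds shown here, the only measured step that bears on this change is an at least 2.7-fold lower number from compound 2 to compound 3 (0.44 log units; beyond the scatter), where a five-membered ring likewise took the place of benzyl on the amide-type nitrogen; because compound 2 gives only a limit, that step is itself a lower bound. The change to compound 4 brings in a five-membered non-aromatic ring with 2 hetero atoms rather than the aromatic 1,2-oxazol-3-yl of compound 3, so the step may differ in size, but a move in the same direction is expected. Compound 4 is estimated at 40000 nM, between 10000 nM and 150000 nM. This expected value means an at least 2.5-fold lower number from compound 2 to compound 4 (0.39 log units; beyond the scatter).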

Compound 4, half-maximal inhibitory concentration: 20000 nM
The estimate for compound 4 lay 2.0-fold (0.30 log units) above the measured number; low and high end bracket the measured number.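

In this assay, a five-membered non-aromatic ring with 2 hetero atoms in place of benzyl on the amide-type nitrogen gives an at least 5.0-fold lower number from compound 2 to compound 4 (0.69 log units; beyond the scatter), so a measurable number at this position does not require the aromatic 1,2-oxazol-3-yl ring of compound 3. The two five-membered rings are not told apart here, as the step is a 1.8-fold lower number from compound 3 to compound 4 (0.26 log units; within the scatter), which lies within the scatter. The size of the step away from benzyl remains only a bound, as compound 2 gives a limit and not a number: the limit of > 100000 nM in this assay, at which 2 of the 4 values shown sit.

The compounds shown leave open whether the hetero atoms of these rings matter or only the absence of benzyl, a question that a plain phenyl on the same nitrogen would help to settle. Also open, from the compounds shown here alone, is what a carboxylic acid or an amine on the five-membered ring would do to the number.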